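Side-chain amides resting at the assay limit

The source may report more compounds than this note shows. Statements on the series, on what has been measured and on what is new or still open speak of the compounds shown alone.

In a functional assay on PC-3 cells (Homo sapiens) for antiproliferative activity, read by MTT assay, with a stated time of 24 h (a lower number here means a stronger inhibitor, a higher number a weaker inhibitor), compound 1 (`CCn1c(C(=O)NCC(=O)OC)ccc1C(CC)(CC)c1ccc(OCS(=O)(=O)c2ccccc2)c(C)c1`) gives > 50000 nM, which is a limit of the assay. Compound 2 (`CCn1c(C(=O)NCCNC(=O)OC(C)(C)C)ccc1C(CC)(CC)c1ccc(OCS(=O)(=O)c2ccccc2)c(C)c1`) gives > 50000 nM, again a limit, and this is where it stands. Both values sit there, as the limit of > 50000 nM in this assay, at which 2 of the 2 values shown sit, records. Compound 3 (`CCn1c(C(=O)N[C@@H](C)CO)ccc1C(CC)(CC)c1ccc(OCS(=O)(=O)c2ccccc2)c(C)c1`) differs from compound 2 on the amide-type nitrogen: 1-(hydroxymethyl)ethyl in place of 2-((tert-butoxycarbonyl)amino)ethyl on an amide-type nitrogen. Within the data shown here, the only measured step bearing on this change is a step that the two limits leave unreadable from compound 1 to compound 2, so its size offers no guide. No change beyond the scatter is therefore expected, and the estimated step is a number no higher from compound 2 to compound 3 (the limit leaves the size open). Compound 3 is estimated at 50000 nM, with an expected range of 15000 nM to 100000 nM.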

Compound 3, half-maximal inhibitory concentration: 9520 nM
Beside the measured number, compound 3's estimate is 5.3-fold (0.72 log units) above it, and the stated range ends above it.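

Working notes: in this assay, 1-(hydroxymethyl)ethyl on the amide-type nitrogen brings an at least 5.2-fold lower number from compound 2 to compound 3 (0.72 log units; beyond the scatter), and also an at least 5.2-fold lower number from compound 1 to compound 3 (0.72 log units; beyond the scatter). This position can therefore move the read-out, which the two earlier compounds could not show, as each rests at a limit: the limit of > 50000 nM in this assay, at which 2 of the 3 values shown sit.

As far as these compounds go, whether the step belongs to the hydroxymethyl, the branching methyl or the defined stereocentre stays open. Also open, from the compounds shown here alone, is how a free amine, a carboxylic acid or a longer hydroxyalkyl chain on this nitrogen would read.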